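The source may report more compounds than this note shows. Statements on the series, on what has been measured and on what is new or still open speak of the compounds shown alone.

Compound 2 `COc1cc(-c2nnc3n2NC(c2ccco2)C(C(=O)c2ccc(F)cc2)S3)cc(OC)c1OC` is the starting point. In a functional assay on HepG2 cells (Homo sapiens) for cytotoxicity, read by MTT assay, with a stated time of 48 h (a lower number here means a stronger inhibitor, a higher number a weaker inhibitor), compound 2 gives > 100000 nM, which is a limit of the assay rather than a number. Compound 1 `COc1cc(C(=O)C2Sc3nnc(-c4cc(OC)c(OC)c(OC)c4)n3NC2c2ccco2)cc(OC)c1OC` likewise gives > 100000 nM, again a limit. Both sit at the limit of > 100000 nM in this assay, at which 2 of the 3 values shown sit, so compound 2 cannot be placed more exactly than at that boundary. Compound 3 `COc1cc(-c2nnc3n2NC(c2cccs2)C(C(=O)c2ccc(F)cc2)S3)cc(OC)c1OC` gives 54200 nM, and the step of an at least 1.8-fold lower number from compound 2 to compound 3 (0.26 log units; that floor lies within the scatter) concerns the saturated ring carbon. The step that the two limits leave unreadable from compound 1 to compound 2 is the only one touching the carbonyl carbon, where compound 4 `COc1cc(-c2nnc3n2NC(c2ccco2)C(C(=O)c2ccco2)S3)cc(OC)c1OC` differs from compound 2 by furan-2-yl in place of 4-fluorophenyl on a carbonyl carbon. No readable step therefore guides this change. Compound 4 is expected to give 100000 nM, between 40000 nM and 300000 nM. That corresponds to an expected step of a number no higher from compound 2 to compound 4 (the limit leaves the size open), none beyond the scatter.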

Compound 4, half-maximal inhibitory concentration: > 100000 nM
Compound 4: no number, only a limit (the forecaster's own chance of this, stated with the estimate: 60%); the middle value sits exactly at the limit.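

No step from compound 2 to compound 4 or from compound 1 to compound 4 can be read, because all three compounds give only a limit: the limit of > 100000 nM in this assay, at which 3 of the 4 values shown sit.

Going by these compounds, whether furan-2-yl in place of 4-fluorophenyl on a carbonyl carbon changes the result at all stays open.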